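The source may report more compounds than this note shows. Statements on the series, on what has been measured and on what is new or still open speak of the compounds shown alone.

Three compounds have been measured so far:
compound 1, `O=C(O)c1ccc(NC(=O)[C@H](CC2CCCC2)n2cnc(S(=O)(=O)C3CC3)c2)nc1`, 0.6 10^-6 cm/s
compound 2, `O=C(O)c1ccc(NC(=O)[C@H](CC2CCCCC2)n2cnc(S(=O)(=O)C3CC3)c2)nc1`, 0.5 10^-6 cm/s
compound 3, `O=C(O)c1ccc(NC(=O)[C@H](CC2CCCCC2)n2cnc(S(=O)(=O)C3CCC3)c2)nc1`, 0.3 10^-6 cm/s

All three were tested in an ADME assay on MDCKII-LE cells (Canis lupus familiaris) for permeability; on this read-out lower numbers stand for lower permeability and higher numbers for higher permeability. Compound 2 gives the second highest of the three numbers; its nearest neighbour is compound 1 and its furthest is compound 3, and both gaps stay within the scatter, so the three compounds cannot be told apart on this read-out.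

Compound 4, `O=C(O)c1ccc(NC(=O)[C@H](CC2CCOCC2)n2cnc(S(=O)(=O)C3CC3)c2)nc1`, has not yet been measured. It differs from compound 2 in one place: oxan-4-yl in place of cyclohexyl on a saturated chain carbon, two bonds along the chain from an aromatic nitrogen and a carbonyl carbon. Among the compounds with values here, two measured steps bear on this. The step from compound 1 to compound 2, a 1.2-fold lower number from compound 1 to compound 2 (0.08 log units; within the scatter), exchanged one carbon ring for another at the same saturated chain carbon and stayed within the scatter. The step from compound 2 to compound 3, a 1.7-fold lower number from compound 2 to compound 3 (0.22 log units; within the scatter), exchanged a ring elsewhere and also stayed within the scatter. Neither step gives grounds to expect a number beyond the scatter for compound 4. Compound 4 is therefore estimated to give 0.4 10^-6 cm/s, with a range from 0.2 10^-6 cm/s to 0.8 10^-6 cm/s. That estimate means an expected step of a 1.3-fold lower number from compound 2 to compound 4 (0.10 log units; within the scatter).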

Compound 4, apparent permeability in the MDCKII-LE assay: 0.9 10^-6 cm/s
Compound 4: middle estimate off by 2.3-fold (0.35 log units), on the low side; measured number outside the range, above it.
By their numbers in the MDCKII-LE assay, from the lowest: compounds 3, 2, 1 and 4 (each within the scatter of the next, the first and the last beyond it).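

In the MDCKII-LE assay, oxan-4-yl in place of cyclohexyl gives a 1.8-fold higher number from compound 2 to compound 4 (0.26 log units; within the scatter), and oxan-4-yl in place of cyclopentyl gives a 1.5-fold higher number from compound 1 to compound 4 (0.18 log units; within the scatter). The earlier change at this saturated chain carbon only exchanged one carbon ring for another, whereas this one puts an oxygen into the ring and adds a hydrogen-bond acceptor, and even so the number stays within the scatter of both carbon-ring compounds. The exchange is far from silent in a physicochemical assay for lipophilicity, at pH 7.4 (on this read-out higher numbers stand for higher lipophilicity and lower numbers for lower lipophilicity), where compound 2 gives -0.25 and compound 4 gives -1.85, so this position tolerates a large drop in lipophilicity with no change in the MDCKII-LE assay that can be told from scatter, at least for this one pair: the measured distribution coefficient of compound 2, -0.25, and of compound 4, -1.85, a number 1.60 log units lower (beyond the scatter)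

What the compounds shown leave open is whether other groups at this place would behave the same way, such as an amine in the ring, as in piperidin-4-yl, or a hydroxyl group on the cyclohexyl ring. Also open, from the compounds shown here alone, is whether oxan-4-yl would give a similar result alongside cyclobutyl on the sulfonyl sulfur, or in a compound with an amide in place of the carboxylic acid that all four share.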